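Swapping Cyclopentylamino for Phenoxy: an Expected Modest Shift

This account rests on a few compounds, and the source may have more. Where it says the series, first, only, none or still open, it means among the compounds named here.

In a functional assay on HCT-116 cells (Homo sapiens) for antiproliferative activity (on this read-out lower numbers stand for stronger inhibition of growth and higher numbers for weaker inhibition of growth), compound 2 `O=C(NC1CC1)c1ccc(-c2cnn3c(NCC4CCOCC4)nc(NC4CCCC4)nc23)cc1` gives 390 nM, the lowest of the two numbers available. Among the measured compounds shown here, compound 3 `O=C(NC1CC1)c1ccc(-c2cnn3c(NCC4CCOCC4)nc(NC4CCCC4)nc23)cc1F` gives 850 nM, and the step of a 2.2-fold higher number from compound 2 to compound 3 (0.34 log units; beyond the scatter) is the only measured single-point change in this set. Compound 1 `CC(C)C(=O)Nc1ccc(-c2cnn3c(NCC4CCOCC4)nc(OC4CCCC4)nc23)cc1` has "not determined" (no result reported) in this assay. Compound 4 `O=C(NC1CC1)c1ccc(-c2cnn3c(NCC4CCOCC4)nc(Oc4ccccc4)nc23)cc1` differs from compound 2 in one place: phenoxy in place of cyclopentylamino on an aromatic carbon. For the measured compounds named here, no measured step bears on this exchange, so the only guidance is that the single known step was modest. For compound 4 a small weakening is therefore expected, a 2.1-fold higher number from compound 2 to compound 4 (0.31 log units; beyond the scatter). The estimate for compound 4 in this assay is 800 nM, with a range from 250 nM to 3000 nM.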

Compound 4, concentration for 50% growth inhibition: 200 nM
The estimate for compound 4 lay 4.0-fold (0.60 log units) above the measured number; the measured number lies below the stated range.
By their numbers in this assay, from the lowest: compounds 4 and 2 (each within the scatter of the next); then compound 3.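

In this assay, a 2.0-fold lower number from compound 2 to compound 4 (0.29 log units; within the scatter) shows that phenoxy can take the place of cyclopentylamino on this aromatic carbon, between two ring nitrogen atoms, without a change beyond the scatter. In this one pair, therefore, neither the hydrogen-bond donor of cyclopentylamino nor its non-aromatic ring is needed to keep the number at this level. Nothing available explains this result. As far as these compounds go, whether a smaller methoxy group or a pyridyloxy ring would also hold this level remains open. So does whether the fluoro step would carry over to the phenoxy compound.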